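The compounds below may be only part of what the source reports. "The series", "measured", "known", "first", "only" and "open" are said of these compounds alone.

In a functional assay on B16 cells (Mus musculus) for antiproliferative activity, with a stated time of 72 h (on this read-out lower numbers stand for stronger inhibition and higher numbers for weaker inhibition), compound 1 `OC[C@H]1O[C@@H](n2cnc3c(NCc4ccccc4F)ncnc32)[C@H](O)[C@@H]1O` gives > 166000 nM as a limit of the assay rather than a number. Compound 2 `OC[C@H]1O[C@@H](n2cnc3c(NCc4cccc(F)c4)ncnc32)[C@H](O)[C@@H]1O` shares the same core, and its entry reads "not determined" (no result reported) so it offers nothing to compare. Compound 3 `OC[C@H]1O[C@@H](n2cnc3c(NCc4ccc(Cl)cc4)ncnc32)[C@H](O)[C@@H]1O` gives > 166000 nM as a limit too. Compound 3 therefore sits at the limit of > 166000 nM in this assay, at which 2 of the 3 values shown sit, and has no number of its own.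

The next structure is compound 4 `OC[C@H]1O[C@@H](n2cnc3c(NCc4ccccc4Br)ncnc32)[C@H](O)[C@@H]1O` with the change 2-bromophenyl in place of 4-chlorophenyl on a saturated chain carbon bound to a nitrogen on an aromatic ring which puts 2-bromophenyl in place of 4-chlorophenyl on a saturated chain carbon bound to a nitrogen on an aromatic ring. Within the data shown here, the only measured step that bears on this is a step that the two limits leave unreadable from compound 1 to compound 3 and it gives no size to carry forward. Neither halogen swap so far has produced a measurable number, so no real gain is expected. The expected step that the limit leaves unreadable from compound 3 to compound 4 is only an estimate, with no direction expected beyond the scatter, and another reading that is just a limit is likely. The estimate for compound 4 is 200000 nM with an expected range from 80000 nM to 500000 nM at this stage.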

Compound 4, half-maximal inhibitory concentration: > 166000 nM
Compound 4: only a limit was reported; the forecaster's own chance of this, stated with the estimate: 85%; the middle value does not contradict the limit.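

Compound 1, compound 3 and compound 4 each give only a limit of the assay, so no step among them can be read: the limit of > 166000 nM in this assay, at which 3 of the 4 values shown sit.

The compounds shown leave open how far apart these three truly lie in this assay, and whether any change at this place on the shared core gives a measurable number.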